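Amine tail swap on the shared core

The source may hold more compounds than are shown below. What is called first, only, known or untested is meant among the compounds shown, and "the series" means these compounds.

Measured compounds:
compound 1 `CN1CCN(CCCCOc2c(O)cc3oc(-c4ccccc4)cc(=O)c3c2O)CC1` gives 93700 nM
compound 2 `CN1CCN(CCCCOc2c(OCc3ccccc3)cc3oc(-c4ccccc4)cc(=O)c3c2O)CC1` gives 2500 nM
compound 3 `COc1cc2oc(-c3ccccc3)cc(=O)c2c(O)c1OCCCCN1CCN(C)CC1` gives 36700 nM

All three numbers come from a functional assay on HepG2 cells (Homo sapiens) for antiproliferative activity, read by MTT assay, with a stated time of 48 h; a higher number here means a weaker inhibitor, a lower number a stronger inhibitor. Compound 3 stands second highest of the three: the nearest is compound 1, with the step of a 2.6-fold lower number from compound 1 to compound 3 (0.41 log units; beyond the scatter), and the furthest is compound 2, with the step of a 15-fold higher number from compound 2 to compound 3 (1.17 log units; beyond the scatter). The large change between compound 1 and compound 2, a 37-fold lower number from compound 1 to compound 2 (1.57 log units; beyond the scatter), comes from benzyl in place of hydrogen on an oxygen on an aromatic ring.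

Compound 4 `COc1cc2oc(-c3ccccc3)cc(=O)c2c(O)c1OCCCN1CCCCC1` differs from compound 3 only in the amine-bearing chain: piperidin-1-yl in place of (4-methylpiperazin-1-yl)methyl on a saturated chain carbon, three bonds along the chain from an oxygen on an aromatic ring. Going by the values given here, none of the measured steps touches this part of the molecule; every one of them alters the group on the other oxygen on an aromatic ring. Among the compounds with values here, there is therefore no measured step that bears on the change from compound 3 to compound 4, and no direction can be read from the data. The expected step of a 1.2-fold lower number from compound 3 to compound 4 (0.09 log units; within the scatter) is accordingly set near zero, within the scatter. Compound 4 is estimated at 30000 nM, with a range from 9000 nM to 100000 nM in this assay.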

Compound 4, half-maximal inhibitory concentration: 22300 nM
Beside the measured number, compound 4's estimate is 1.3-fold (0.13 log units) above it; measured number inside the range.
By their numbers in this assay, from the lowest: compound 2; then compounds 4 and 3 (each within the scatter of the next); then compound 1.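

In this assay, going by these compounds alone, the amine-bearing chain, which no earlier step touched, tolerates piperidin-1-yl in place of (4-methylpiperazin-1-yl)methyl on a saturated chain carbon, three bonds along the chain from an oxygen on an aromatic ring, with the result lying inside the usual scatter (a 1.6-fold lower number from compound 3 to compound 4 (0.22 log units; within the scatter)). This swap alters the amine ring and the chain together, so the contribution of each cannot be separated from this one pair. No measurement among these compounds accounts for the outcome.

From the compounds shown here alone, it remains open whether the same swap would hold with the benzyl group of compound 2 on the other oxygen. Going by these compounds, it is also open how a morpholine ring, a dimethylamino group or a longer chain would behave at this position.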